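The source may hold more compounds than are shown below. What is called first, only, known or untested is meant among the compounds shown, and "the series" means these compounds.

Among the measured compounds shown here, in a functional assay on T29Kt1 cells (Homo sapiens) for cytotoxicity, read by sulforhodamine B assay, with a stated time of 3 days (on this read-out lower numbers stand for stronger inhibition and higher numbers for weaker inhibition), three compounds have numbers so far. Compound 1 `O=Cc1cn(Cc2ccc(Cl)cc2)c2ccc(Cl)cc12` gives 10000 nM, compound 2 `OCc1cn(Cc2ccc(Cl)cc2)c2ccccc12` gives 79 nM, and compound 3 `OCc1cn(Cc2cccc(Br)c2)c2ccccc12` gives 32 nM. Compound 2 therefore holds the middle place of the three. Compound 3 is its nearest neighbour, with a lower number, and that gap lies beyond the scatter. Compound 1 is furthest away, with a far higher number, also beyond the scatter. Compound 4 `Cc1ccc(Cn2cc(CO)c3ccccc32)cc1` departs from compound 2 at one point: methyl in place of chloro on an aromatic carbon, para to a large group. For the measured compounds named here, no measured pair shows this exchange, so the data give no direct guide to it. With only that to go on, no step beyond the scatter is expected in either direction, and compound 2 at 79 nM remains the reference point. The estimated change is a 1.1-fold lower number from compound 2 to compound 4 (0.05 log units; within the scatter). For compound 4 the estimate is 70 nM, with an expected range of 25 nM to 220 nM.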

Compound 4, half-maximal inhibitory concentration: 150 nM
Beside the measured number, compound 4's estimate is 2.1-fold (0.33 log units) below it; the range from low to high includes it.
By their numbers in this assay, from the lowest: compound 3; then compounds 2 and 4 (each within the scatter of the next); then compound 1.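

Among the compounds shown here, this is the first direct reading of a change on this ring. In this assay, methyl in place of chloro on an aromatic carbon, para to a large group, gives a 1.9-fold higher number from compound 2 to compound 4 (0.28 log units; within the scatter), so at this position the two groups cannot be told apart and the chloro is not needed to keep the number in this range. No measurement at hand gives a reason for this result.

The compounds shown leave open whether this holds only for small groups of one heavy atom or also for a methoxy, a trifluoromethyl, an amine or a carboxylic acid at the same carbon. They also do not show whether the same exchange would give so small a step with a different substitution on the shared core.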